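A few compounds are considered here, and "the series" means these few. Any claim that something is new, unique, unknown or untested is made for them only; others in the source may bear on it.

Measured so far in an in vivo ADME assay on the whole organism for pharmacokinetics, with Rattus norvegicus as the target, at a dose of 5 mg/kg by the oral route; a lower number here means that a smaller share of the oral dose reaches the circulation, a higher number that a larger share of the oral dose reaches the circulation:

Compound 1 `Cc1ccc([C@H](C(=O)N(C)C)N2C(=O)[C@@H](C3Cc4ccccc4C3)NC(=O)[C@H]2CC(C)C)cn1` gives 57%
Compound 2 `COc1ccc([C@H](C(=O)N2CCOCC2)N2C(=O)[C@@H](C3Cc4ccccc4C3)NC(=O)[C@H]2CC(C)C)cn1` gives 88%

Compound 2 stands highest of the two, with compound 1 lower by more than the usual scatter. Compound 3 `COc1ccc([C@H](C(=O)N(C)C)N2C(=O)[C@@H](C3Cc4ccccc4C3)NC(=O)[C@H]2CC(C)C)cn1` carries dimethylamino in place of morpholin-4-yl on a carbonyl carbon and is still to be measured. Within the data shown here, no measured pair shows this change alone. The expectation of a fall rests on compound 1 at 57% which also holds dimethylamino on a carbonyl carbon. The expected step is a number 20 percentage points lower from compound 2 to compound 3 (beyond the scatter) by this estimate. For compound 3 the estimated value is 68% within an expected range from 45% to 88% in this account.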

Compound 3, oral bioavailability: 62%
The estimate for compound 3 lay 6 percentage points above the measured number; the range from low to high includes it.
By their numbers in this assay, from the lowest: compounds 1 and 3 (each within the scatter of the next); then compound 2.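

In this assay, the change on the carbonyl carbon now stands alone: dimethylamino in place of morpholin-4-yl gives a number 26 percentage points lower from compound 2 to compound 3 (beyond the scatter), so the difference at this position carries through to oral exposure. Methoxy in place of methyl on an aromatic carbon gives a number 5 percentage points higher from compound 1 to compound 3 (within the scatter), so this change does not separate the two compounds. Nothing at hand accounts for either step. The compounds shown leave open how a piperidin-1-yl or pyrrolidin-1-yl group would read on the same carbonyl carbon. They also leave open whether a chloro group on that aromatic carbon would fit with methyl and methoxy.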